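The source may report more compounds than this note shows. Statements on the series, on what has been measured and on what is new or still open speak of the compounds shown alone.

Measured compounds:
Compound 1 `O=C(Nc1ccccc1)c1ccc(C(=O)O)nc1` gives 26500 nM
Compound 2 `O=C(Nc1cccc(Cl)c1)c1ccc(C(=O)O)nc1` gives 32200 nM

In an assay on isolated protein (Gallus gallus) for inhibition of transmembrane prolyl 4-hydroxylase (Homo sapiens) (a lower number here means a stronger inhibitor, a higher number a weaker inhibitor), compound 1 and compound 2 give numbers within the scatter of each other, so compound 1 does not stand apart. Compound 3 `O=C(Nc1ccc([N+](=O)[O-])cc1)c1ccc(C(=O)O)nc1` differs from compound 1 in one place: nitro in place of hydrogen on an aromatic carbon. Among the compounds with values here, one measured step bears on this change, the one that also replaces a hydrogen on an aromatic carbon of the same kind of ring, a 1.2-fold higher number from compound 1 to compound 2 (0.08 log units; within the scatter). That step stayed within the scatter, so no step beyond the scatter is expected here either. Compound 3 is therefore estimated at 25000 nM, between 10000 nM and 60000 nM, an expected step of a 1.1-fold lower number from compound 1 to compound 3 (0.03 log units; within the scatter).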

Compound 3, half-maximal inhibitory concentration: 44000 nM
For compound 3 the middle estimate is 1.8-fold (0.25 log units) below the measured one; measured number inside the range.
By their numbers in this assay, from the lowest: compounds 1, 2 and 3 (each within the scatter of the next).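

At this place on the ring, para to a large group, nitro brings 3 heavy atoms where there was only a hydrogen, and this assay shows a 1.7-fold higher number from compound 1 to compound 3 (0.22 log units; within the scatter) as the result. Thus a second replacement of hydrogen, now by a group other than chloro, leaves the number within the scatter. Nothing measured here gives a reason for this.

Going by these compounds, it remains open whether an amine or a methoxy group at this place would also stay within the scatter. Nitro elsewhere on the ring is also an open case.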